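The compounds below may be only part of what the source reports. "The series", "measured", "known", "first", "only" and "open" are said of these compounds alone.

Measured so far in an ADME assay on Huh-7 cells (Homo sapiens) for cytotoxicity; on this read-out higher numbers stand for lower toxicity in this test and lower numbers for higher toxicity in this test:
- compound 1 `O=c1cc(CNCc2ccccc2Br)oc2ccc(O)c(O)c12` gives > 100000 nM, a limit of the assay rather than a number.
- compound 2 `O=c1cc(CNCc2ccccc2O)oc2ccc(O)c(O)c12` gives > 100000 nM, also a limit of the assay.

Compound 1 stands only at a limit, so its true value is not known. The step that the two limits leave unreadable from compound 1 to compound 2 cannot be read either, since the limit of > 100000 nM in this assay, at which 2 of the 2 values shown sit, holds both values. The change to compound 3 `O=c1cc(CNCc2cccc(I)c2)oc2ccc(O)c(O)c12` is 3-iodophenyl in place of 2-bromophenyl on a saturated chain carbon bound to an amine nitrogen. Among the compounds with values here, no measured step bears directly on it; the only sign is that both measured compounds sit at the limit, so compound 3 is expected to show no step beyond the scatter, a step that the limit leaves unreadable from compound 1 to compound 3. Compound 3 is therefore estimated at 150000 nM, within 60000 nM to 400000 nM, most likely again as a limit.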

Compound 3, half-maximal cytotoxic concentration: > 100000 nM
Compound 3 was reported as a limit; the forecaster's own chance of this, stated with the estimate: 80%; the middle value does not contradict the limit.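

No step between compound 1, compound 2 and compound 3 can be read, as all three stand at a limit rather than a number: the limit of > 100000 nM in this assay, at which 3 of the 3 values shown sit.

The compounds shown leave open whether exchanging these aromatic groups changes the result in this assay at all.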